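The source may report more compounds than this note shows. Statements on the series, on what has been measured and on what is new or still open speak of the compounds shown alone.

Among the compounds with values here, compound 2, `COC(=O)c1ccc(C2SCC(=O)N2c2ccc(N3CCN(S(=O)(=O)c4ccc(OC)cc4)CC3)cn2)c(OC)c1`, stands at the weaker end of the two numbers so far: in a functional assay on NALM-6 cells (Homo sapiens) for antiproliferative activity, read by MTT assay and trypan blue exclusion, with a stated time of 72 h (a lower number here means a stronger inhibitor, a higher number a weaker inhibitor), compound 2 gives 29400 nM. Its nearest neighbour is compound 1, `COC(=O)c1ccc(C2SCC(=O)N2c2ccc(N3CCN(S(=O)(=O)c4cc(Cl)ccc4Cl)CC3)cn2)c(OC)c1`, which in this assay gives 27400 nM; the step of a 1.1-fold higher number from compound 1 to compound 2 (0.03 log units; within the scatter) does not rise above the scatter, so the two compounds are indistinguishable on this read-out.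

Compound 3, `COC(=O)c1ccc(C2SCC(=O)N2c2ccc(N3CCN(S(=O)(=O)c4ccc([N+](=O)[O-])cc4)CC3)cn2)c(OC)c1`, is the next variation on the same sulfonyl-bound ring: nitro in place of methoxy on an aromatic carbon. Within the data shown here, only one measured step bears on this change, the swap of the whole aryl group on the sulfonyl sulfur from compound 1 to compound 2, and that step was a 1.1-fold higher number from compound 1 to compound 2 (0.03 log units; within the scatter), within the scatter. Among the measured compounds shown here, that step replaced the entire ring, whereas here a single group on the ring is exchanged, so it is only an indirect guide; still, the one comparison available shows the ring on the sulfonyl sulfur tolerating change without any shift beyond the noise.

Compound 3 is therefore expected to give about 28000 nM in this assay, within a range of 12000 nM to 65000 nM. The expected step of a 1.1-fold lower number from compound 2 to compound 3 (0.02 log units; within the scatter) is thus no movement beyond the scatter.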

Compound 3, half-maximal inhibitory concentration: > 100000 nM
Compound 3 gave a limit, no number (the forecaster's own chance of this, stated with the estimate: 10%); middle value at least 3.5-fold (0.55 log units) from the limit.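

In this assay, compound 3 reaches only a limit of the assay and not a number: the limit of > 100000 nM in this assay, at which 1 of the 3 values shown sits.

Exchanging methoxy for nitro on this aromatic carbon gives an at least 3.4-fold higher number from compound 2 to compound 3 (0.53 log units; beyond the scatter), and putting 4-nitrophenyl in place of 2,5-dichlorophenyl on the sulfonyl sulfur gives an at least 3.6-fold higher number from compound 1 to compound 3 (0.56 log units; beyond the scatter). These are the first changes on this ring to go beyond the scatter, whereas the earlier step, a 1.1-fold higher number from compound 1 to compound 2 (0.03 log units; within the scatter), had shown no difference, so what the ring on the sulfonyl sulfur carries does matter on this read-out, and 4-nitrophenyl stands apart from the other two aryl groups.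

The compounds shown do not tell how far compound 3 lies past its limit, nor whether the loss belongs to nitro alone or would also appear with another group at this place, such as an amine, a nitrile or a carboxylic acid. They also leave open whether the same exchange would have the same outcome on a ring with its group elsewhere, and they give no cause for the loss.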